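The compounds below may be only part of what the source reports. "The series", "measured", "known", "first", "only" and "open" are said of these compounds alone.

In an assay on SH-EP1 cells for displacement of a labelled ligand from Neuronal acetylcholine receptor; alpha4/beta2 (Homo sapiens), read by scintillation counting (on this read-out higher numbers stand for weaker inhibition and lower numbers for stronger inhibition), compound 3 `O=C([C@H]1C[C@@H]1F)N1CC2CC(C1)N2` gives 5.4 nM, the lowest of the three numbers available. Compound 2 `CCC(=O)N1CC2CC(C1)N2` gives 6 nM, and the two sit within the scatter of one another, as a 1.1-fold lower number from compound 2 to compound 3 (0.05 log units; within the scatter) shows. Compound 1 `CC(=O)N1CC2CC(C1)N2` gives 150 nM, and both a 25-fold lower number from compound 1 to compound 2 (1.40 log units; beyond the scatter) and a 28-fold lower number from compound 1 to compound 3 (1.44 log units; beyond the scatter) are large. Compound 4 `C[C@@H]1C[C@@H]1C(=O)N1CC2CC(C1)N2` differs from compound 3 by a group of 4 heavy atoms (4 carbon; one three-membered non-aromatic ring of carbon only) in place of a group of 4 heavy atoms (3 carbon, 1 fluorine; one three-membered non-aromatic ring of carbon only), on a carbonyl carbon. The step that bears most on this change is a 1.1-fold lower number from compound 2 to compound 3 (0.05 log units; within the scatter), which swapped one small group on the carbonyl carbon for another and stayed within the scatter; the large steps start from compound 1 only. Compound 4 is therefore expected to show no step beyond the scatter in this assay, namely a 1.1-fold higher number from compound 3 to compound 4 (0.05 log units; within the scatter). The estimate for compound 4 in this assay is 6 nM, within 2 nM to 18 nM.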

Compound 4, inhibition constant: 22 nM
Beside the measured number, compound 4's estimate is 3.7-fold (0.56 log units) below it; the measured number lies above the stated range.
By their numbers in this assay, from the lowest: compounds 3 and 2 (each within the scatter of the next); then compound 4; then compound 1.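

In this assay this place on the carbonyl carbon now separates two groups of equal heavy-atom count, each with a three-membered ring: a 4.1-fold higher number from compound 3 to compound 4 (0.61 log units; beyond the scatter) follows from the all-carbon group replacing 2-fluorocyclopropyl, so the ring alone does not set the number. The all-carbon group also stands apart from ethyl, with a 3.7-fold higher number from compound 2 to compound 4 (0.56 log units; beyond the scatter) on that side, yet it stays clear of methyl, with a 6.8-fold lower number from compound 1 to compound 4 (0.83 log units; beyond the scatter) on the other. Nothing available here explains these differences. Going by these compounds, whether unsubstituted cyclopropyl, 2-chlorocyclopropyl or a longer chain such as propyl would fall with compound 3 or with compound 4 stays open. So does the effect of the other stereoisomers of these ring groups.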